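Compound 1 to compound 4: propyl on the amine nitrogen

The source may report more compounds than this note shows. Statements on the series, on what has been measured and on what is new or still open speak of the compounds shown alone.

Values in a functional assay on A549 cells (Homo sapiens) for cytotoxicity, read by MTT assay, with a stated time of 72 h (on this read-out higher numbers stand for weaker inhibition and lower numbers for stronger inhibition), stand as follows:
compound 1 `COc1ccc(/C=C2\CNC/C(=C\c3ccc(OC)c(OC)c3)C2=O)cc1OC` gives 2900 nM
compound 2 `COc1cc(/C=C2\CNC/C(=C\c3cc(OC)c(OC)c(OC)c3)C2=O)cc(OC)c1OC` gives 1200 nM
compound 3 `COc1cc(/C=C2\CN(C)C/C(=C\c3cc(OC)c(OC)c(OC)c3)C2=O)cc(OC)c1OC` gives 1700 nM

Compound 1 stands level with compound 3 within the scatter, and its number lies above that of compound 2 by more than the scatter. Compound 4 `CCCN1C/C(=C\c2ccc(OC)c(OC)c2)C(=O)/C(=C/c2ccc(OC)c(OC)c2)C1` differs from compound 1 by propyl in place of hydrogen on an amine nitrogen in a ring in the form of propyl in place of hydrogen on an amine nitrogen in a ring. Among the compounds with values here, no measured compound carries propyl. Within the data shown here, the one measured step at such a nitrogen, methyl in place of hydrogen, is a 1.4-fold higher number from compound 2 to compound 3 (0.15 log units; within the scatter) and gives no sign of a large change. In this assay the expected step is a 1.0-fold higher number from compound 1 to compound 4 (0.01 log units; within the scatter) and so none beyond the scatter. Compound 4 is estimated at 3000 nM within an expected range (1200 nM to 7500 nM).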

Compound 4, half-maximal inhibitory concentration: 4200 nM
The estimate for compound 4 lay 1.4-fold (0.15 log units) below the measured number; measured number inside the range.
By their numbers in this assay, from the lowest: compounds 2, 3, 1 and 4 (each within the scatter of the next, the first and the last beyond it).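

Propyl in place of hydrogen on an amine nitrogen in a ring gives, in this assay, a 1.4-fold higher number from compound 1 to compound 4 (0.16 log units; within the scatter). The earlier compounds shown here showed only methyl at such a nitrogen, and on another core; this result shows that the core of compound 1 also carries propyl there without a change beyond the scatter. No evidence at hand bears on the reason for this result.

On these data alone, whether a longer chain such as hexyl, or a chain ending in an amine or a carboxylic acid, would also stay within the scatter remains open. So does the effect of propyl on the core of compound 2.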